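Carbamate series at alpha4/beta2: the ring-nitrogen methyl

The compounds below may be only part of what the source reports. "The series", "measured", "known", "first", "only" and "open" are said of these compounds alone.

Measured so far in an assay on Hippocampus for displacement of a labelled ligand from Neuronal acetylcholine receptor; alpha4/beta2 (Rattus norvegicus); a lower number here means a stronger inhibitor, a higher number a weaker inhibitor:
compound 1 `CN(C)C[C@H]1CN(C)C(=O)O1`: 2200 nM
compound 2 `CN(C)C[C@@H]1CN(C)C(=O)O1`: 2660 nM
compound 3 `CN1C[C@H](C[N+](C)(C)C)OC1=O`: 3100 nM

Compound 1 holds the lowest of the three numbers, but its neighbours sit close: a 1.2-fold higher number from compound 1 to compound 2 (0.08 log units; within the scatter) and a 1.4-fold higher number from compound 1 to compound 3 (0.15 log units; within the scatter) both lie within the scatter, so no order among the three is claimed. The first of these steps rests on (the fact that compounds 1 and 2 differ only in the configuration as drawn), a change of configuration at the saturated ring carbon and nothing else. The second replaces the group on the saturated chain carbon with the larger one of compound 3.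

Compound 4 `CN(C)C[C@H]1CNC(=O)O1` differs from compound 1 by hydrogen in place of methyl on an amide-type nitrogen in a ring. Neither measured step touches that nitrogen: one alters configuration at the ring carbon, the other the substituent on the chain carbon, and both stayed within the scatter. The measured steps thus give no direct read on removing the methyl from the amide-type nitrogen in the ring, and the expectation leans on compound 1 alone. For compound 4 in this assay the number is estimated at 2500 nM, within 700 nM to 9000 nM, which means an expected step of a 1.1-fold higher number from compound 1 to compound 4 (0.06 log units; within the scatter), not beyond the scatter but with a wide range either way.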

Compound 4, inhibition constant: 450 nM
Compound 4: the middle estimate sits 5.6-fold (0.74 log units) above what was measured; the whole stated range lies above it.
By their numbers in this assay, from the lowest: compound 4; then compounds 1, 2 and 3 (each within the scatter of the next).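

In this assay the amide-type nitrogen in the ring is the only place in this series where a single change moves the number beyond the scatter: hydrogen in place of methyl gives a 4.9-fold lower number from compound 1 to compound 4 (0.69 log units; beyond the scatter) and thereby sets this position apart from the other two places examined. Neither the change of configuration at the saturated ring carbon, with a 1.2-fold higher number from compound 1 to compound 2 (0.08 log units; within the scatter) as its step, nor the larger group on the saturated chain carbon, with a 1.4-fold higher number from compound 1 to compound 3 (0.15 log units; within the scatter) as its step, moved the number beyond the scatter. For this core the methyl on that nitrogen therefore goes with a higher number than hydrogen does, though this rests on one pair, and nothing available bears on the cause of the step.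

On these data alone, whether ethyl or a longer chain on the amide-type nitrogen would raise the number further than methyl does remains open. Also open, as far as these compounds go, is whether hydrogen in place of methyl at this nitrogen gives a similar step with the opposite configuration of compound 2 or with the larger group of compound 3.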